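Pyridin-4-yl in place of pyridin-3-yl on compound 1

A few compounds are considered here, and "the series" means these few. Any claim that something is new, unique, unknown or untested is made for them only; others in the source may bear on it.

In a functional assay on KB cells (Homo sapiens) for antiproliferative activity, read by MTT assay, with a stated time of 72 h, in the presence of a further agent that is not named here (a higher number here means a weaker inhibitor, a lower number a stronger inhibitor), compound 1 (`Nc1nc2[nH]c(CCSCC(=O)NCc3cccnc3)cc2c(=O)[nH]1`) gives 37500 nM. Within the scatter of that value, compound 2 (`Nc1nc2[nH]c(CCSCCC(=O)NCc3ccncc3)cc2c(=O)[nH]1`) gives 45600 nM, while compound 3 (`Nc1nc2[nH]c(CCSCCC(=O)NCc3cccnc3)cc2c(=O)[nH]1`) gives a far lower 648 nM. The move to compound 4 (`Nc1nc2[nH]c(CCSCC(=O)NCc3ccncc3)cc2c(=O)[nH]1`) is pyridin-4-yl in place of pyridin-3-yl on a saturated chain carbon bound to an amide-type nitrogen. Among the compounds with values here, one measured step bears on it: a 70-fold lower number from compound 2 to compound 3 (1.85 log units; beyond the scatter), the same exchange in the opposite direction on a different chain. Read in reverse, that step points to a higher number. However, compound 1 at 37500 nM lacks the low value that compound 3 shows and already stands level with compound 2, so only a small part of that step is carried over. The expected step is a 1.3-fold higher number from compound 1 to compound 4 (0.12 log units; within the scatter), a slightly higher number that stays within the scatter. Compound 4 is estimated at 50000 nM, with an expected range of 12000 nM to 200000 nM.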

Compound 4, half-maximal inhibitory concentration: 14100 nM
Estimate against measurement, compound 4: 3.5-fold (0.55 log units) above; the measured number falls inside the stated range.
By their numbers in this assay, from the lowest: compound 3; then compound 4; then compounds 1 and 2 (each within the scatter of the next).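

In this assay, pyridin-4-yl in place of pyridin-3-yl on the chain of compound 1 gives a 2.7-fold lower number from compound 1 to compound 4 (0.42 log units; beyond the scatter), so the order of the two pyridines seen between compound 2 and compound 3 does not carry over to this chain. The exchange is therefore not a fixed increment at this position: its direction and size both depend on the chain that carries the ring, and the two steps differ clearly: the same change on two cores in this assay, a 70-fold lower number (1.85 log units; beyond the scatter) from compound 2 to compound 3 and a 2.7-fold higher number (0.42 log units; beyond the scatter) from compound 4 to compound 1, 190-fold (2.27 log units) apart, beyond the scatter of two such steps

From the compounds shown here alone, whether pyridin-2-yl or plain phenyl on the saturated chain carbon bound to an amide-type nitrogen would follow either pattern remains open, as does the behaviour of both pyridines on a longer chain. These four compounds do not show what underlies the dependence on the chain.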